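The source may report more compounds than this note shows. Statements on the series, on what has been measured and on what is new or still open speak of the compounds shown alone.

Compound 1 `COc1ccc(-c2cnc(NC(=O)c3cccnc3)n2C)cc1` is a small amide built on a shared core. In a toxicity assay on THP-1 cells (Homo sapiens) for inhibition (a lower number here means that less compound is tolerated, a higher number that more compound is tolerated), compound 1 gives only a limit of the assay, > 100000 nM, and no number. Compound 2 `Cn1c(-c2ccccc2)cnc1NC(=O)c1ncc[nH]1` carries a different amide on the same core. In this assay compound 2 also gives only a limit, > 100000 nM. Among the measured compounds shown here, both measured compounds thus sit at the same edge of what the assay can report (the limit of > 100000 nM in this assay, at which 2 of the 2 values shown sit), and no step between them can be read. Compound 3 `COc1ccc(-c2cnc(NC(=O)CCc3ccccc3)n2C)cc1` has not yet been measured. It differs from compound 1 in one place: phenethyl in place of pyridin-3-yl on a carbonyl carbon. For the measured compounds named here, with both known values stopping at the limit, there is no measured step to lean on. The step from compound 1 to compound 3 is expected to be a number no higher from compound 1 to compound 3 (the limit leaves the size open), that is, nothing beyond the scatter of this assay. Compound 3 is estimated to give 100000 nM, in a range from 30000 nM to 300000 nM.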

Compound 3, half-maximal cytotoxic concentration: > 100000 nM
Compound 3: a limit, no number; the forecaster's own chance of this, stated with the estimate: 70%; the middle value sits exactly at the limit.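

Among the compounds shown here, compound 3 stops at a limit just as compound 1 does, so no step between them can be read in this assay: the limit of > 100000 nM in this assay, at which 3 of the 3 values shown sit. The compounds shown leave open whether any change to the amide on the shared core gives a measurable half-maximal cytotoxic concentration.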